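From Propoxy to Methylsulfanyl in a Cytotoxicity Series

The source may hold more compounds than are shown below. What is called first, only, known or untested is meant among the compounds shown, and "the series" means these compounds.

Of the compounds shown here, two have been measured so far. In a functional assay on SK-MEL-5 cells (Homo sapiens) for cytotoxicity (on this read-out lower numbers stand for an effect already at smaller amounts and higher numbers for an effect only at larger amounts of compound), compound 1 `COc1cc(/C=C/c2ccc(SC)cc2)cc(OC)c1OC` gives 2.8 uM. In the same test, compound 2 `CCCOc1ccc(/C=C\c2cc(OC)c(OC)c(OC)c2)cc1` gives 1.4 uM. These two values lie within the usual scatter of each other, so compound 2 cannot be separated from compound 1 on these numbers.

The next compound is compound 3 `COc1cc(/C=C\c2ccc(SC)cc2)cc(OC)c1OC`, which differs from compound 2 at a single place: methylsulfanyl in place of propoxy on an aromatic carbon. Methylsulfanyl stands in place of propoxy on an aromatic carbon, para to a large group. Within the data shown here, no measured pair shows this exchange on its own, so the expectation rests on judgement and remains uncertain. Taking compound 2 at 1.4 uM as the starting point, a lower number is expected in this assay, by a margin beyond the scatter. The expected change is a 7.0-fold lower number from compound 2 to compound 3 (0.85 log units; beyond the scatter). The estimated value for compound 3 is 0.2 uM. The estimated range for compound 3 runs from 0.02 uM to 1.5 uM.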

Compound 3, concentration for half-maximal effect: 4 uM
Beside the measured number, compound 3's estimate is 20-fold (1.30 log units) below it; measured number outside the range, above it.
By their numbers in this assay, from the lowest: compounds 2, 1 and 3 (each within the scatter of the next, the first and the last beyond it).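

In this assay, methylsulfanyl in place of propoxy on an aromatic carbon, para to a large group, gives a 2.9-fold higher number from compound 2 to compound 3 (0.46 log units; beyond the scatter). This is a modest step, but it lies beyond the scatter and points to a higher number, something the two earlier compounds could not show, as their values lay within the scatter of each other and they differed in more than one place. The double bond can now be read on its own, and its configuration yields no separable difference, with a 1.4-fold higher number from compound 1 to compound 3 (0.15 log units; within the scatter); this pair speaks to configuration alone, and that reading rests on one thing: the fact that compounds 1 and 3 differ only in the configuration as drawn

The compounds shown leave open how an amine, a hydroxyl or a chain longer than propoxy would behave on the same aromatic carbon, so the single exchange gives no trend across groups at this position. Among these compounds, they also leave open whether the configuration of the double bond would matter as little with propoxy as it does with methylsulfanyl, as the series holds only one such pair.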